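Removing the Trifluoromethoxy Group from Compound 2

This account rests on a few compounds, and the source may have more. Where it says the series, first, only, none or still open, it means among the compounds named here.

Among the compounds with values here, compound 2 `CC(=O)Nc1cc(-c2ccc(OC[C@@H](N)CC(C)C)c(OC(F)(F)F)c2)ccn1` gives 0.45 nM in an assay on HEK293F cells for inhibition of AP2-associated protein kinase 1 (Homo sapiens), read by Western blot, with a stated time of 3 h (on this read-out lower numbers stand for stronger inhibition and higher numbers for weaker inhibition), the lowest of the two numbers measured so far. The nearest is compound 1 `CC(=O)Nc1cc(-c2ccc(OC[C@@H](N)CC(C)C)c(C)c2)ccn1`, which gives 1.1 nM in this assay. Within the data shown here, the only step available, a 2.4-fold lower number from compound 1 to compound 2 (0.39 log units; beyond the scatter), shows that exchanging methyl for trifluoromethoxy at this position lowered the number modestly.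

Compound 3 `CC(=O)Nc1cc(-c2ccc(OC[C@@H](N)CC(C)C)cc2)ccn1` differs from compound 2 by hydrogen in place of trifluoromethoxy on an aromatic carbon, the change sitting on an aromatic carbon of a six-membered aromatic ring of carbon only, ortho to the (2-amino-4-methylpentyl)oxy group. Among the measured compounds shown here, no measured step covers hydrogen at this carbon. Since the trifluoromethoxy group is the feature that separated compound 2 from compound 1 by a 2.4-fold lower number from compound 1 to compound 2 (0.39 log units; beyond the scatter), its removal is expected to bring compound 3 back toward the number of compound 1, a step of a 2.7-fold higher number from compound 2 to compound 3 (0.43 log units; beyond the scatter). Compound 3 is therefore estimated at 1.2 nM, within a range of 0.4 nM to 3.5 nM.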

Compound 3, half-maximal inhibitory concentration: 8.1 nM
Compound 3: the middle estimate sits 6.8-fold (0.83 log units) below what was measured, and the stated range ends below it.
By their numbers in this assay, from the lowest: compound 2; then compound 1; then compound 3.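

In this assay the carbon ortho to the (2-amino-4-methylpentyl)oxy group turns out to matter more than the exchange of methyl for trifluoromethoxy alone suggested. Hydrogen in place of trifluoromethoxy gives an 18-fold higher number from compound 2 to compound 3 (1.26 log units; beyond the scatter) and hydrogen in place of methyl gives a 7.4-fold higher number from compound 1 to compound 3 (0.87 log units; beyond the scatter) so both groups go with a lower number than hydrogen, and most of the gain lies in having either group at this carbon rather than in which of the two it is. No evidence is available on what lies behind this difference.

As far as these compounds go, whether chlorine, methoxy or a nitrile at this carbon would match methyl and trifluoromethoxy or go lower still remains open. So does whether the same order among the three holds when the acetamide of the shared core is replaced by another amide.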